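The source may hold more compounds than are shown below. What is called first, only, known or untested is meant among the compounds shown, and "the series" means these compounds.

Measured compounds:

Compound 1 `CC(=O)OC(C)n1cnc2c(Cl)nc(N)nc21` — in a functional assay on HT-29 cells (Homo sapiens) for inhibition (on this read-out lower numbers stand for stronger inhibition and higher numbers for weaker inhibition), compound 1 gives > 500000 nM, which is a limit of the assay rather than a number.
Compound 2 `CC(O)n1cnc2c(Cl)nc(I)nc21` — in this assay compound 2 gives > 500000 nM, again a limit.
Compound 3 `CC(=O)OC(C)n1cnc2c(N)nc(I)nc21` — in this assay compound 3 gives > 500000 nM, again a limit.

For compound 1, then, no number is known at all, only a limit, and the two other values shown are limits as well; all three sit at the limit of > 500000 nM in this assay, at which 3 of the 3 values shown sit. No two of these compounds differ in only one place, so there is no measured step, and the values show nothing more than that none of the three reaches a measurable inhibition in this assay.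

Compound 4 `CC(=O)OC(C)n1cnc2c(Cl)nc(F)nc21` is the one still to be measured. It differs from compound 1 by fluoro in place of amino on an aromatic carbon. Going by the values given here, with no measured step to lean on, the expectation rests on the shared core alone, and since every compound on this core so far sits at the limit of > 500000 nM in this assay, at which 3 of the 3 values shown sit, the step from compound 1 to compound 4 is expected to be none beyond the scatter, a number no higher from compound 1 to compound 4 (the limit leaves the size open). Compound 4 is therefore estimated at 500000 nM, within a range from 100000 nM to 1000000 nM, most likely reported only as a limit again.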

Compound 4, half-maximal inhibitory concentration: 75900 nM
Compound 4: the middle estimate sits 6.6-fold (0.82 log units) above what was measured; measured number below the stated range.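

Swapping amino for fluoro on the aromatic carbon between two ring nitrogen atoms gives, in this assay, an at least 6.5-fold lower number from compound 1 to compound 4 (0.81 log units; beyond the scatter). This shows that the position is not silent: a change at this one carbon is enough to bring a compound on the shared core to a measurable number, whereas the other compounds shown stay at a limit: the limit of > 500000 nM in this assay, at which 3 of the 4 values shown sit. Compound 1 has only a limit and no number, so the step gives a minimum size rather than an exact one.

On these data alone, it remains open whether a methoxy group or a methyl group on this carbon would also give a measurable number, and so whether fluoro itself matters or simply the absence of amino. As far as these compounds go, it is also open whether fluoro would have the same effect if the chloro group were replaced by another group.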